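Replacing the Acrylamide Arm at the Para Position

The compounds below may be only part of what the source reports. "The series", "measured", "known", "first", "only" and "open" are said of these compounds alone.

Measured compounds:
compound 1 `C=CS(=O)(=O)NCc1ccc(C(=O)Nc2ccc(C)c(Nc3nccc(-c4cccnc4)n3)c2)cc1`: 7710 nM
compound 2 `C=CC(=O)Nc1ccc(C(=O)Nc2ccc(C)c(Nc3nccc(-c4cccnc4)n3)c2)cc1`: 5600 nM

In an ADME assay on BaF3 cells (Mus musculus) for cytotoxicity, read by CellTiter-Glo and CCK-8 assay, with a stated time of 72 h (on this read-out lower numbers stand for stronger inhibition of growth and higher numbers for weaker inhibition of growth), compound 2 gives 5600 nM, the lowest of the two numbers, while compound 1 gives 7710 nM. The step of a 1.4-fold lower number from compound 1 to compound 2 (0.14 log units; within the scatter) is within the scatter, so the two compounds cannot be told apart on these data.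

Compound 3 `Cc1ccc(NC(=O)c2ccc(CN(CCN(C)C)C(=O)C(C)C)cc2)cc1Nc1nccc(-c2cccnc2)n1` has not yet been measured. It differs from compound 2 at the same place where compounds 1 and 2 differ: ((2-(dimethylamino)ethyl)(isopropylcarbonyl)amino)methyl in place of (vinylcarbonyl)amino on an aromatic carbon.

Going by the values given here, only the step of a 1.4-fold lower number from compound 1 to compound 2 (0.14 log units; within the scatter) bears on this change, and it shows that swapping one group at this position left the number essentially unchanged. Among the compounds with values here, no measured step covers a group as large as the one entering here, so the expectation is uncertain. Compound 3 is therefore estimated to give 9000 nM (range 3000 nM to 30000 nM), a step of a 1.6-fold higher number from compound 2 to compound 3 (0.21 log units; within the scatter) that is expected to stay close to the scatter.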

Compound 3, concentration for 50% growth inhibition: > 10000 nM
Compound 3 was reported as a limit; the forecaster's own chance of this, stated with the estimate: 10%; middle value at least 1.1-fold (0.04 log units) away from the limit.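

Compound 3 is recorded as a limit, not as a number: the limit of > 10000 nM in this assay, at which 1 of the 3 values shown sits. The comparison therefore gives only floors, an at least 1.7-fold higher number from compound 2 to compound 3 (0.25 log units; that floor lies within the scatter) and an at least 1.2-fold higher number from compound 1 to compound 3 (0.11 log units; that floor lies within the scatter), so each true gap could be small or large. What this adds is that a much larger group at this position, ((2-(dimethylamino)ethyl)(isopropylcarbonyl)amino)methyl, which carries no vinyl group, gives no sign of a lower number in this assay.

The compounds shown leave open which part of that group matters, the 2-(dimethylamino)ethyl chain or the isopropylcarbonyl, and whether a vinylcarbonyl on the same chain would read differently. Also open, on these data alone, is how a simple amine or a carboxylic acid would read at this position.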